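The source may report more compounds than this note shows. Statements on the series, on what has been measured and on what is new or still open speak of the compounds shown alone.

Measured in a functional assay on PC-3 cells (Homo sapiens) for cytotoxicity, read by MTT assay, with a stated time of 72 h; a higher number here means a weaker inhibitor, a lower number a stronger inhibitor:
compound 1 `O=S(=O)(c1ccccc1)c1nc2ccccc2nc1Nc1ccccc1` gives 590 nM
compound 2 `Nc1ccc(Nc2nc3ccccc3nc2S(=O)(=O)c2ccccc2)cc1` gives 5830 nM
compound 3 `Cc1ccc(S(=O)(=O)c2nc3ccccc3nc2Nc2ccccc2)cc1` gives 1060 nM

Compound 3 stands second highest of the three numbers; compound 1 lies within the scatter of it, and compound 2 lies beyond the scatter on the high side. Two single-point steps are known: a 1.8-fold higher number from compound 1 to compound 3 (0.25 log units; within the scatter), methyl in place of hydrogen on an aromatic carbon, stayed within the scatter, whereas a 9.9-fold higher number from compound 1 to compound 2 (0.99 log units; beyond the scatter), amino in place of hydrogen on an aromatic carbon, was modest. Compound 4 `Cc1ccc(S(=O)(=O)c2nc3ccccc3nc2Nc2ccc(Cl)cc2)cc1` differs from compound 3 by chloro in place of hydrogen on an aromatic carbon. Among the measured compounds shown here, no measured step introduces a chloro, so neither precedent matches closely; the nearer one in kind, a small neutral group added, is a 1.8-fold higher number from compound 1 to compound 3 (0.25 log units; within the scatter). Compound 4 is therefore expected to show a step of a 1.1-fold higher number from compound 3 to compound 4 (0.05 log units; within the scatter), not beyond the scatter. The estimate for compound 4 is 1200 nM, range 400 nM to 4000 nM.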

Compound 4, half-maximal inhibitory concentration: 9660 nM
The estimate for compound 4 lay 8.1-fold (0.91 log units) below the measured number; the whole stated range lies below it.
By their numbers in this assay, from the lowest: compounds 1 and 3 (each within the scatter of the next); then compounds 2 and 4 (each within the scatter of the next).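

In this assay, chloro in place of hydrogen on the anilino ring, para to a large group, is not silent like the methyl change on the other aromatic ring: a 9.1-fold higher number from compound 3 to compound 4 (0.96 log units; beyond the scatter). The amino change on the anilino ring, a 9.9-fold higher number from compound 1 to compound 2 (0.99 log units; beyond the scatter), is of similar size and in the same direction, so both listed substitutions on this ring raise the number, and no compound shown goes against this. Nothing shown explains the rise.

Going by these compounds, whether fluoro, methoxy or a carboxylic acid at this place would also raise the number stays open. So does whether chloro gives a similar step without the methyl on the other ring.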